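Aminoquinoxaline series: aryloxy to benzylamino exchange at the core

This account rests on a few compounds, and the source may have more. Where it says the series, first, only, none or still open, it means among the compounds named here.

Compound 1 `Nc1cc(N)c2nc(-c3ccccc3)c(Oc3ccc(Cl)c(Cl)c3)nc2c1` carries a 3,4-dichlorophenoxy group on the shared core. In a functional assay on SW-620 cells (Homo sapiens) for inhibition, read by sulforhodamine B assay, with a stated time of 48 h (on this read-out lower numbers stand for stronger inhibition of growth and higher numbers for weaker inhibition of growth), compound 1 gives 9770 nM, the highest of the two numbers recorded; the nearest neighbour, compound 3 `COc1cc(CNc2nc3cc(N)cc(N)c3nc2-c2ccccc2)cc(OC)c1OC`, gives 1550 nM in this assay, a gap that lies beyond the scatter. Compound 2 `CCOC(=O)[C@H](CCC(=O)O)NC(=O)c1ccc(CNc2nc3cc(N)cc(N)c3nc2-c2ccccc2)cc1` reaches only the limit of this assay and returns < 100000 nM, which is a limit and not a number (the limit of < 100000 nM in this assay, at which 1 of the 3 values shown sits).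

Compound 4 `Nc1cc(N)c2nc(-c3ccccc3)c(NCc3ccc(F)cc3)nc2c1` is the next point. It differs from compound 1 in one place: (4-fluorobenzyl)amino in place of 3,4-dichlorophenoxy on an aromatic carbon. For the measured compounds named here, no measured pair in this set covers exactly this exchange, so the expectation rests on what compound 1 and compound 3 show: the two benzylamino compounds with numbers, compound 3 included, sit at or below compound 1, while compound 2 as a benzylamino compound gives only a limit.

For compound 4 the expected step in this assay is a lower number than compound 1 by a 2.8-fold lower number from compound 1 to compound 4 (0.45 log units; beyond the scatter), a step beyond the scatter in the direction of stronger inhibition of growth. The estimate for compound 4 in this assay is 3500 nM, with a range from 800 nM to 15000 nM.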

Compound 4, concentration for 50% growth inhibition: 2190 nM
Compound 4: the middle estimate sits 1.6-fold (0.20 log units) above what was measured; the measured number falls inside the stated range.
By their numbers in this assay, from the lowest: compounds 3 and 4 (each within the scatter of the next); then compound 1.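

In this assay, for the compounds shown here, the exchange of 3,4-dichlorophenoxy for (4-fluorobenzyl)amino gives a 4.5-fold lower number from compound 1 to compound 4 (0.65 log units; beyond the scatter), the first step in this set that can be read at a single place, here on the aromatic carbon next to the ring nitrogen and ortho to the phenyl group. The step shows that this position responds to the group it carries, even though both groups hold 9 heavy atoms and one six-membered aromatic ring of carbon only, and that the size of the response is modest. The entering group brings a hydrogen-bond donor that the leaving group lacks, but nothing at hand ties the step to that difference or to any other cause.

Going by these compounds alone, this exchange alters the connecting atoms and the ring substituents together, so the single step cannot divide its size between them. A 4-fluorophenoxy or a (3,4-dichlorobenzyl)amino group at the same carbon would separate the two, and a longer chain such as (4-fluorophenethyl)amino would show whether the distance from the core to the ring also counts.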